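The compounds below may be only part of what the source reports. "The series", "measured", "known", "first", "only" and "open" are said of these compounds alone.

The shared core carries a side chain and a substituent on one aromatic carbon. Compound 1 `Cc1cccc2nc(N3CCN(C)CC3)oc12` bears a methyl there, and in a functional assay on ileum (strain Hartley) for agonist activity at 5-hydroxytryptamine receptor 3A (Cavia porcellus) (a higher number here means a more potent compound, by a factor of ten per unit of this negative logarithm, a lower number a less potent compound), compound 1 gives 5.48. Compound 2 `COc1cc(C)cc2nc(N3CCN(C)CC3)oc12` carries a methoxy on that aromatic carbon together with a further methyl, and in this assay compound 2 gives 6.13. Compound 3 `CC(C)c1cccc2nc(N3CCN(C)CC3)oc12` carries an isopropyl on the aromatic carbon. In this assay compound 3 reaches only the limit of the assay, < 4, so no number is known for it. Compound 3 thus stands at the limit where one of the three values sits (the limit of < 4 in this assay, at which 1 of the 3 values shown sits). The step of a number at least 1.48 log units lower from compound 1 to compound 3 (beyond the scatter) shows that enlarging the methyl to an isopropyl costs a great deal.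

Compound 4 `COc1cccc2nc(N3CCN(C)CC3)oc12` is not yet measured. The change from compound 3 is methoxy in place of isopropyl on an aromatic carbon. For the measured compounds named here, compound 4 differs from compound 2 only by the further methyl that compound 2 carries; no step between them is given, but compound 2 shows 6.13 and compound 1 shows 5.48, both measured numbers. Because a number at least 1.48 log units lower from compound 1 to compound 3 (beyond the scatter) was large, its reversal is expected to be large too: for compound 4 the step of a number at least 1.70 log units higher from compound 3 to compound 4 (beyond the scatter) is expected in this assay. Compound 4 is accordingly estimated at 5.7, between 5 and 6.3.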

Compound 4, negative logarithm of the half-maximal effective concentration: < 4
Compound 4 ended at the assay's limit; the forecaster's own chance of this, stated with the estimate: 5%; at least 1.70 log units between middle value and limit.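

In this assay compound 4 gives < 4, which is a limit of the assay and not a number, and it joins compound 3 there: the limit of < 4 in this assay, at which 2 of the 4 values shown sit.
Removing the further methyl while the methoxy stays gives a number at least 2.13 log units lower from compound 2 to compound 4 (beyond the scatter), so the methoxy alone does not carry the potency seen with compound 2, and the further methyl matters in this pair. Methoxy in place of methyl on the aromatic carbon gives a number at least 1.48 log units lower from compound 1 to compound 4 (beyond the scatter), so among the three groups shown at this place without the further methyl, isopropyl, methoxy and methyl, only methyl gives a measured number.

The compounds shown leave open how far compound 3 and compound 4 lie under the limit, so the step between them cannot be read. They also leave open whether an ethyl or an amine on this aromatic carbon would give a measured number, and whether the further methyl would have the same effect alongside a group other than methoxy.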